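Swapping a Thiourea for a Dichlorophenyl Urea

The source may hold more compounds than are shown below. What is called first, only, known or untested is meant among the compounds shown, and "the series" means these compounds.

Within the data shown here, compound 3 `NC(=O)c1c(NC(=O)c2ccccc2Cl)sc2c1CCN(C(=S)Nc1ccccc1I)C2` gives 4430 nM in a functional assay on HL-60 cells (Homo sapiens) for antiproliferative activity, with a stated time of 24 h (a lower number here means a stronger inhibitor, a higher number a weaker inhibitor), the second highest of the three numbers so far. Its nearest neighbour is compound 2 `NC(=O)c1c(NC(=O)c2ccccc2Cl)sc2c1CCN(Cc1c(Cl)cccc1Cl)C2`, which in this assay gives 4850 nM; the furthest is compound 1 `NC(=O)c1c(NC(=O)c2ccccc2Cl)sc2c1CCN(Cc1ccccc1Cl)C2`, which in this assay gives 2900 nM. The move toward compound 4 `NC(=O)c1c(NC(=O)c2ccccc2Cl)sc2c1CCN(C(=O)Nc1c(Cl)cccc1Cl)C2` is a group of 11 heavy atoms (7 carbon, 1 nitrogen, 1 oxygen, 2 chlorine; one six-membered aromatic ring of carbon only) in place of a group of 10 heavy atoms (7 carbon, 1 nitrogen, 1 sulfur, 1 iodine; one six-membered aromatic ring of carbon only), on an amine nitrogen in a ring. Among the measured compounds shown here, three measured steps bear on what sits on that ring nitrogen or on the aryl ring carried by it: a 1.5-fold higher number from compound 1 to compound 3 (0.18 log units; within the scatter), a 1.1-fold lower number from compound 2 to compound 3 (0.04 log units; within the scatter), and a 1.7-fold higher number from compound 1 to compound 2 (0.22 log units; within the scatter). Each of these changes stayed within the scatter, so no step beyond the scatter is expected for this change either. Compound 4 is therefore expected to give 4000 nM, with a range from 1800 nM to 9000 nM, an expected step of a 1.1-fold lower number from compound 3 to compound 4 (0.04 log units; within the scatter).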

Compound 4, half-maximal inhibitory concentration: 17700 nM
Compound 4: the middle estimate sits 4.4-fold (0.65 log units) below what was measured, and the stated range ends below it.
By their numbers in this assay, from the lowest: compounds 1, 3 and 2 (each within the scatter of the next); then compound 4.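

Among the changes on the ring amine nitrogen, this is the first to move the number beyond the scatter in this assay: (2,6-dichlorophenyl)carbamoyl gives a 4.0-fold higher number from compound 3 to compound 4 (0.60 log units; beyond the scatter) in this comparison. The same group gives a 3.6-fold higher number from compound 2 to compound 4 (0.56 log units; beyond the scatter) in place of 2,6-dichlorobenzyl, and a 6.1-fold higher number from compound 1 to compound 4 (0.79 log units; beyond the scatter) in place of 2-chlorobenzyl, so the position is not indifferent to its substituent. Nothing available explains this difference. Compound 3 and compound 4 differ in both the sulfur or oxygen of the linker and the aryl halogens, so those contributions remain unseparated. On these data alone, how an acetyl group or a carboxylic acid would fare on this nitrogen remains open.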